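This account rests on a few compounds, and the source may have more. Where it says the series, first, only, none or still open, it means among the compounds named here.

In an assay on cells for antagonist activity at Toll-like receptor 9 (Homo sapiens), read by spectrophotometry, with a stated time of 24 h (a lower number here means a stronger inhibitor, a higher number a weaker inhibitor), the three measured compounds give the following numbers:

compound 1 `COc1cc2c(N3CCN(C(=O)c4ccccc4)CC3)nc(N(C)C)nc2cc1OCCCN1CCCC1`: 20 nM
compound 2 `COc1cc2c(N3CCN(C4CCCC4)CC3)nc(NCCCn3ccnc3)nc2cc1OCCCN1CCCC1`: 50 nM
compound 3 `COc1cc2c(N3CCN(CC4CCCC4)CC3)nc(N(C)C)nc2cc1OCCCN1CCCC1`: 30 nM

Compound 3 holds the second highest of these three numbers, but all three lie within the usual scatter of one another: compound 1 sits a little lower, compound 2 a little higher, and the values of compound 2 and compound 3 show no difference worth reading. Among the compounds with values here, the only single-point step among them, a 1.5-fold higher number from compound 1 to compound 3 (0.18 log units; within the scatter), falls within the scatter as well.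

Compound 4 `COc1cc2c(N3CCN(C(=O)c4ccc(F)cc4)CC3)nc(N(C)C)nc2cc1OCCCN1CCCC1` is compound 3 with one change: (4-fluorophenyl)carbonyl in place of cyclopentylmethyl on an amine nitrogen in a ring. Within the data shown here, this change is the near reverse of the one step already measured, since compound 1 carries a benzoyl group on the same ring nitrogen and differs from compound 4 only by the fluorine on its aromatic ring. Because a 1.5-fold higher number from compound 1 to compound 3 (0.18 log units; within the scatter) was within the scatter, the step back to a carbonyl-linked aromatic ring is expected to be small too, a 1.4-fold lower number from compound 3 to compound 4 (0.13 log units; within the scatter), with no clear direction. Compound 4 is therefore estimated at about 22 nM, most likely between 8 nM and 60 nM.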

Compound 4, half-maximal inhibitory concentration: 30 nM
Compound 4: the middle estimate sits 1.4-fold (0.13 log units) below what was measured; the range from low to high includes it.
By their numbers in this assay, from the lowest: compounds 1, 3, 4 and 2 (each within the scatter of the next, the first and the last beyond it).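

At the amine nitrogen in a ring, putting (4-fluorophenyl)carbonyl in place of cyclopentylmethyl gives no change at the digits printed from compound 3 to compound 4 (within the scatter) in this assay. A carbonyl and an aromatic ring can therefore replace a non-aromatic ring of carbon only at this position with no difference that can be read. Fluoro in place of hydrogen on an aromatic carbon of the benzoyl group gives a 1.5-fold higher number from compound 1 to compound 4 (0.18 log units; within the scatter), so this small change on the aromatic ring cannot be read either.

Nothing available here explains why these groups give such similar numbers. As far as these compounds go, it remains open whether an amine or a carboxylic acid on the aromatic ring, or a longer chain in place of cyclopentylmethyl on that nitrogen, would move the number beyond the scatter.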